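This account rests on a few compounds, and the source may have more. Where it says the series, first, only, none or still open, it means among the compounds named here.

Three related compounds have been measured so far in an ADME assay on microsomes from liver (Rattus norvegicus) for metabolic stability; a lower number here means that the compound disappears faster, a higher number that the compound lasts longer. Compound 1 (`CC(C)C(/C=C1\NC(=O)NC1=O)c1ccc(-c2ccc3cccc(F)c3c2)[nH]c1=O`) gives 1.46 h and compound 2 (`CCC(/C=C1\OC(=O)NC1=O)(CC)c1ccc(-c2ccc3cccc(C(C)C)c3c2)[nH]c1=O`) gives 1.88 h as its half-life, and these two values lie within the usual scatter of each other. Compound 3 (`CCC(CC)C(/C=C1\OC(=O)NC1=O)c1ccc(-c2ccc3cccc(F)c3c2)[nH]c1=O`) reads > 3 h and this is a limit of the assay, not a number. Compound 3 therefore stands at the limit of > 3 h in this assay, at which 1 of the 3 values shown sits, and offers a starting point without an exact figure.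

Compound 4 (`O=C1NC(=O)/C(=C/C(c2ccc(-c3ccc4cccc(F)c4c3)[nH]c2=O)C2CCCCC2)O1`) has not been measured yet. It differs from compound 3 in one place, with cyclohexyl in place of pentan-3-yl on a saturated chain carbon bound to an aromatic carbon and a double-bonded chain carbon as the count: cyclohexyl in place of pentan-3-yl on a saturated chain carbon bound to an aromatic carbon and a double-bonded chain carbon. Within the data shown here, no two measured compounds differ in only one place, so no measured step shows what this swap does. Both groups are made of carbon only, and the expected change in this assay is none beyond the scatter, with a slight lean downward. Among the measured compounds shown here, that lean rests on compound 1 at 1.46 h and compound 2 at 1.88 h as the only exact numbers so far. The estimated change is an at least 1.2-fold lower number from compound 3 to compound 4 (0.07 log units; that floor lies within the scatter) and it could still end up as a limit rather than a number. For compound 4 the expected half-life is 2.5 h with an estimated range from 1.3 h to 4.8 h as the outcome.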

Compound 4, half-life: 2.39 h
Estimate against measurement, compound 4: 1.0-fold (0.02 log units) above; measured number inside the range.
By their numbers in this assay, from the lowest: compounds 1, 2 and 4 (each within the scatter of the next). At a limit, above all of these: compound 3.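

In this assay, among these compounds, cyclohexyl in place of pentan-3-yl on a saturated chain carbon bound to an aromatic carbon and a double-bonded chain carbon gives the first single change at this position that can be read at all: an at least 1.2-fold lower number from compound 3 to compound 4 (0.09 log units; that floor lies within the scatter). Compound 3 carries a limit of the assay and not a number: the limit of > 3 h in this assay, at which 1 of the 4 values shown sits. The step is therefore only a floor, and that floor lies within the scatter, so the data do not establish a real difference between the two groups. Compound 4, at 2.39 h, gives this position an exact number with a six-membered non-aromatic ring of carbon only.

From the compounds shown here alone, how far compound 3 truly lies from compound 4 stays unknown, and so does whether the same swap would read alike on a different core. Both groups here are made of carbon alone, so the compounds shown say nothing about how a ring holding oxygen, such as tetrahydropyranyl, or an amine would behave at this position in this assay.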